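The compounds below may be only part of what the source reports. "The series", "measured", "known", "first", "only" and "open" are said of these compounds alone.

Measured compounds
- compound 1, `CN(C)c1ccc(/C=C/c2c(F)cccc2Cl)cn1`, in a functional assay on LS174T cells (Homo sapiens) for antiproliferative activity; on this read-out lower numbers stand for stronger inhibition and higher numbers for weaker inhibition: 4.7 nM
- compound 2, `CN(C)c1ccc(/C=C/c2c(Cl)cccc2Cl)cn1`, in this assay: 30.1 nM
- compound 3, `CN(C)c1ncc(/C=C/c2c(F)cccc2F)cn1`, in this assay: > 200 nM

The value for compound 3 is a limit of this assay and not a number; it sits at the limit of > 200 nM in this assay, at which 1 of the 3 values shown sits.

Compound 1 and compound 2 share a core and differ by chloro in place of fluoro on an aromatic carbon. That change gives a 6.4-fold higher number from compound 1 to compound 2 (0.81 log units; beyond the scatter) in this assay, so the chloro compound stands weaker than its fluoro counterpart in this pair.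

Compound 4, `CN(C)c1ncc(/C=C/c2c(F)cccc2Cl)cn1`, has not yet been measured in this assay. It differs from compound 3 by chloro in place of fluoro on an aromatic carbon. For the measured compounds named here, this is the same kind of change as the one from compound 1 to compound 2, not the same: there the place is meta to a chloro group, here it is meta to a fluoro group. The difference between the core of compound 3 and the core of compound 1 is not broken down here.

Going by the values given here, for compound 4 the expectation rests on two things: compound 3 already reaches only a limit, > 200 nM, and the one comparable change, a 6.4-fold higher number from compound 1 to compound 2 (0.81 log units; beyond the scatter), moved the number upward. Compound 4 is therefore expected to give 500 nM in this assay, most likely again reported only as a limit. The step this implies from compound 3 to compound 4 is estimated as a step that the limit leaves unreadable from compound 3 to compound 4, with a range of 120 nM to 3000 nM expected for compound 4.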

Compound 4, half-maximal inhibitory concentration: > 200 nM
Compound 4: no number, only a limit (the forecaster's own chance of this, stated with the estimate: 75%); the middle value lies beyond the limit too.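

No step from compound 3 to compound 4 can be read in this assay, because both compounds give only a limit and not a number: the limit of > 200 nM in this assay, at which 2 of the 4 values shown sit.

The compounds shown leave open whether chloro in place of fluoro moves the number at all on the core of compound 3, and how any such change would compare with a 6.4-fold higher number from compound 1 to compound 2 (0.81 log units; beyond the scatter).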